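From 3-fluorophenyl to pyridin-3-yl on a shared core

A few compounds are considered here, and "the series" means these few. Any claim that something is new, unique, unknown or untested is made for them only; others in the source may bear on it.

Values in a functional assay on NCI-H460 cells (Homo sapiens) for inhibition, with a stated time of 72 h; a higher number here means a weaker inhibitor, a lower number a stronger inhibitor:
- Compound 1 `COc1ccc(S(=O)(=O)N2CCc3cccc(-c4ccc(N)cc4)c32)cc1`: 288 nM
- Compound 2 `COc1ccc(S(=O)(=O)N2CCc3cccc(-c4ccc(F)c(F)c4)c32)cc1`: 46 nM
- Compound 3 `COc1ccc(S(=O)(=O)N2CCc3cccc(-c4cccc(F)c4)c32)cc1`: 167 nM

The three compounds share a core and differ only in one aromatic group. Compound 3 stands close to compound 1, with a 1.7-fold lower number from compound 1 to compound 3 (0.24 log units; within the scatter). It stands further from compound 2, with a 3.6-fold higher number from compound 2 to compound 3 (0.56 log units; beyond the scatter).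

Compound 4 `COc1ccc(S(=O)(=O)N2CCc3cccc(-c4cccnc4)c32)cc1` has pyridin-3-yl in place of 3-fluorophenyl on an aromatic carbon. Among the compounds with values here, no measured compound has a hetero atom in this ring, so no measured step shows this change directly. The closest guide is the other changes to the same group, which include a 6.3-fold lower number from compound 1 to compound 2 (0.80 log units; beyond the scatter). These steps are modest at most, so no step beyond the scatter is expected in this assay, and either direction remains possible. The estimated change is a 1.4-fold lower number from compound 3 to compound 4 (0.14 log units; within the scatter). The estimate for compound 4 is 120 nM, with an expected range of 30 nM to 400 nM.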

Compound 4, half-maximal inhibitory concentration: 89.6 nM
Compound 4: middle estimate off by 1.3-fold (0.13 log units), on the high side; measured number inside the range.
By their numbers in this assay, from the lowest: compounds 2, 4, 3 and 1 (each within the scatter of the next, the first and the last beyond it).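

Pyridin-3-yl is the first group here to put a hetero atom in this ring, and in this assay the change leaves compound 4 within the scatter of both fluorinated compounds (a 1.9-fold lower number from compound 3 to compound 4 (0.27 log units; within the scatter); a 1.9-fold higher number from compound 2 to compound 4 (0.29 log units; within the scatter)). The aminophenyl compound alone stands clearly apart (a 3.2-fold lower number from compound 1 to compound 4 (0.51 log units; beyond the scatter)). A ring nitrogen with one hydrogen-bond acceptor can therefore replace a fluorinated phenyl ring at this position without a change that these numbers can separate from scatter, and no supporting data explain this result.

The compounds shown leave open whether the place of the ring nitrogen matters, a question that pyridin-4-yl or pyridin-2-yl could answer. They also leave open how a five-membered ring such as thiophene or a saturated ring such as morpholine would behave here.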